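Cyclobutyl for 2-Methylbutyl at the Chain Carbon

The source may report more compounds than this note shows. Statements on the series, on what has been measured and on what is new or still open speak of the compounds shown alone.

Of the compounds shown here, three sharing one core have been measured in an in vitro ADME assay on microsomes from liver (Homo sapiens) for metabolic stability; on this read-out lower numbers stand for a shorter-lived compound and higher numbers for a longer-lived compound. Compound 1 `CC(C)CCn1nc(-c2cccs2)c(O)c(C2=NS(=O)(=O)c3cc(OCC(N)=O)ccc3N2)c1=O` gives 0.383 h in this assay. Compound 2 `CC(C)(F)CCn1nc(-c2cccs2)c(O)c(C2=NS(=O)(=O)c3cc(OCC(N)=O)ccc3N2)c1=O` gives 0.65 h in this assay, and compound 3 `CCC(C)CCn1nc(-c2cccs2)c(O)c(C2=NS(=O)(=O)c3cc(OCC(N)=O)ccc3N2)c1=O` gives 0.417 h. Compound 3 stands second highest of the three numbers: its nearest neighbour is compound 1, with a 1.1-fold higher number from compound 1 to compound 3 (0.04 log units; within the scatter), and its furthest is compound 2, with a 1.6-fold lower number from compound 2 to compound 3 (0.19 log units; within the scatter). The remaining step, a 1.7-fold higher number from compound 1 to compound 2 (0.23 log units; within the scatter), is likewise within the scatter, so none of the three alterations of the chain bound to the aromatic nitrogen has shifted this assay beyond its usual spread.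

Compound 4 `NC(=O)COc1ccc2c(c1)S(=O)(=O)N=C(c1c(O)c(-c3cccs3)nn(CC3CCC3)c1=O)N2` has not yet been measured. It differs from compound 3 by cyclobutyl in place of 2-methylbutyl on a saturated chain carbon bound to an aromatic nitrogen. All three measured steps rework the same chain at the same attachment point and each stayed within the scatter, so for compound 4 no step beyond the scatter is expected in this assay in either direction. The step expected from compound 3 to compound 4 is a 1.0-fold higher number from compound 3 to compound 4 (0.00 log units; within the scatter). Compound 4 is therefore estimated at 0.42 h in this assay, with a range from 0.21 h to 0.85 h.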

Compound 4, half-life: 0.367 h
Compound 4: middle estimate off by 1.1-fold (0.06 log units), on the high side; measured number inside the range.
By their numbers in this assay, from the lowest: compounds 4, 1, 3 and 2 (each within the scatter of the next).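

In this assay, a four-membered ring of carbon now stands at this position, on a saturated chain carbon bound to an aromatic nitrogen, and it remains within the scatter of all three open-chain compounds (a 1.1-fold lower number from compound 3 to compound 4 (0.06 log units; within the scatter); a 1.0-fold lower number from compound 1 to compound 4 (0.02 log units; within the scatter); a 1.8-fold lower number from compound 2 to compound 4 (0.25 log units; within the scatter)). The step from the fluorinated chain is the largest among these four compounds and is still printed as within the scatter, so on this read-out neither the ring nor the fluorine separates any of the four compounds from the others. Nothing available here accounts for how closely these four readings lie together.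

The compounds leave open whether a chain carrying an amine or a carboxylic acid, or a longer chain, at this same place would give a step beyond the scatter. Since the rest of the structure is the same in all four compounds, they also leave open whether a change elsewhere in the shared core would move the number in this assay further than any change seen at this position.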